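From cyclobutyl to 3-methoxypiperidin-1-yl on the carbonyl

The source may hold more compounds than are shown below. What is called first, only, known or untested is meant among the compounds shown, and "the series" means these compounds.

Of the compounds shown here, three sharing one core have been measured in an assay on HEK293 cells for negative allosteric modulation of metabotropic glutamate receptor 5 (Homo sapiens), read by FLIPR; on this read-out lower numbers stand for stronger inhibition and higher numbers for weaker inhibition. Compound 1 `Cc1ccc(S(=O)(=O)N2CC(c3nc(-c4cccc(Cl)c4)no3)C2)cc1` gives 920 nM in this assay. Compound 2 `O=C(C1CCC1)N1CC(c2nc(-c3cccc(Cl)c3)no2)C1` gives 1500 nM in this assay. Among the two numbers, compound 2 stands at the higher one, and its nearest neighbour is compound 1, whose number lies within the usual scatter of it, so the two cannot be told apart. Compound 3 `O=C(C1CCC(C(F)(F)F)CC1)N1CC(c2nc(-c3cccc(Cl)c3)no2)C1` did not yield a number in this assay but only the limit > 10000 nM.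

Compound 4 `COC1CCCN(C(=O)N2CC(c3nc(-c4cccc(Cl)c4)no3)C2)C1` has not yet been measured. It differs from compound 2 in one place: 3-methoxypiperidin-1-yl in place of cyclobutyl on a carbonyl carbon. Going by the values given here, no measured pair covers this change. The expectation leans toward weaker inhibition, because compound 3 with a larger group on the carbonyl carbon already sits at the limit of > 10000 nM in this assay, at which 1 of the 3 values shown sits, though the entering group also brings a hydrogen-bond acceptor that the cyclobutyl lacked. The expected step of a 2.3-fold higher number from compound 2 to compound 4 (0.37 log units; beyond the scatter) is toward a higher number, somewhat beyond the scatter but short of the limit. Compound 4 is thus estimated at 3500 nM, within a range from 1200 nM to 10000 nM.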

Compound 4, half-maximal inhibitory concentration: 1830 nM
Compound 4: the middle estimate sits 1.9-fold (0.28 log units) above what was measured, within the range that was stated.
By their numbers in this assay, from the lowest: compounds 1, 2 and 4 (each within the scatter of the next). At a limit, above all of these: compound 3.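

In this assay, placing 3-methoxypiperidin-1-yl instead of cyclobutyl on the carbonyl carbon gives a 1.2-fold higher number from compound 2 to compound 4 (0.09 log units; within the scatter), so the read-out does not separate the two compounds. The earlier compounds shown here left it unclear whether a group larger than cyclobutyl could stand at this position without a clear loss of inhibition, and this step shows that at least one such group, a six-membered ring with a hetero atom and a hydrogen-bond acceptor, can do so. Larger size on the carbonyl carbon therefore does not by itself lead to the limit, and compound 3 remains the only compound at one, which is not a number: the limit of > 10000 nM in this assay, at which 1 of the 4 values shown sits.

The compounds shown leave open whether the methoxy group contributes anything to the value of compound 4, which a plain piperidin-1-yl or a morpholin-4-yl on the same carbonyl carbon would help to settle. They also leave open whether the trifluoromethyl group is what sets compound 3 apart, a question that a plain cyclohexyl in its place would address.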